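Swapping methyl for methoxy on a shared thiazole-bearing core

A few compounds are considered here, and "the series" means these few. Any claim that something is new, unique, unknown or untested is made for them only; others in the source may bear on it.

Three close relatives of one core have been tested in a functional assay on MCF7 cells (Homo sapiens) for cytotoxicity, read by sulforhodamine B assay, with a stated time of 48 h; a higher number here means a weaker inhibitor of growth, a lower number a stronger inhibitor of growth. Compound 1 `Cc1ccc(-c2ccc(C)n2-c2ccc(-c3nc4ccccc4s3)cc2)cc1` gives 2500 nM in this assay. Compound 2 `COc1ccc(-c2ccc(C)n2-c2ccc(-c3nc4ccccc4s3)cc2)cc1` gives 2780 nM, and compound 3 `COc1ccc2nc(-c3ccc(-n4c(C)ccc4-c4ccc(C)cc4)cc3)sc2c1` gives 2570 nM. Compound 3 stands among its two neighbours with no separation that can be trusted: its number agrees with those of compound 1 and compound 2 within the scatter of repeated measurements, so none of the three can be set apart.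

Compound 4 `COc1ccc(-c2ccc(C)n2-c2ccc(-c3nc4ccc(OC)cc4s3)cc2)cc1` differs from compound 3 in one place: methoxy in place of methyl on an aromatic carbon. The same exchange has already been made once on the same core, going a 1.1-fold higher number from compound 1 to compound 2 (0.05 log units; within the scatter), and the other available step, a 1.0-fold higher number from compound 1 to compound 3 (0.01 log units; within the scatter), was just as small. Since the matching step from compound 1 to compound 2 stayed within the scatter, the expected outcome for compound 4 is no step beyond the scatter, a 1.1-fold higher number from compound 3 to compound 4 (0.04 log units; within the scatter), with the number estimated at 2800 nM in this assay, within a range from 1500 nM to 5500 nM.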

Compound 4, concentration for 50% growth inhibition: 3090 nM
Beside the measured number, compound 4's estimate is 1.1-fold (0.04 log units) below it; measured number inside the range.
By their numbers in this assay, from the lowest: compounds 1, 3, 2 and 4 (each within the scatter of the next).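

Exchanging 4-methylphenyl for 4-methoxyphenyl now has a second reading, on the core of compound 3, and in this assay it gives the same kind of small result as the first: the same change on two cores in this assay, a 1.1-fold higher number (0.05 log units; within the scatter) from compound 1 to compound 2 and a 1.2-fold higher number (0.08 log units; within the scatter) from compound 3 to compound 4, 1.1-fold (0.03 log units) apart, within the scatter of two such steps

The other change, methoxy in place of hydrogen on the shared core, also has a second reading, a 1.1-fold higher number from compound 2 to compound 4 (0.05 log units; within the scatter), and it agrees with its earlier counterpart: the same change on two cores in this assay, a 1.0-fold higher number (0.01 log units; within the scatter) from compound 1 to compound 3 and a 1.1-fold higher number (0.05 log units; within the scatter) from compound 2 to compound 4, 1.1-fold (0.03 log units) apart, within the scatter of two such steps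

With a 1.2-fold higher number from compound 3 to compound 4 (0.08 log units; within the scatter) as well, carrying both methoxy groups together in compound 4 produces no step beyond the scatter, so on these two cores neither change separates the compounds.

On these data alone, whether an amine, a carboxylic acid or a longer chain such as butoxy in this place would move the number beyond the scatter stays open. The compounds shown span too narrow a range to tell which parts of the core matter for growth inhibition.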